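The source may report more compounds than this note shows. Statements on the series, on what has been measured and on what is new or still open speak of the compounds shown alone.

In an assay on isolated protein for inhibition of Alpha-2C adrenergic receptor (Homo sapiens) (on this read-out lower numbers stand for stronger inhibition and higher numbers for weaker inhibition), only one of the three measured compounds of this series gives a number. Among the measured compounds shown here, compound 3 `CN(CCCCN(C[C@H]1Cc2ncccc2CN1)[C@H]1CCCc2cccnc21)C1CCOCC1` gives 8400 nM, the sole number. Compound 1 `CN(CCCCN(C[C@H]1Cc2ncccc2CN1)[C@H]1CCCc2cccnc21)C1CCC(F)(F)CC1` gives only a limit, > 30000 nM, in this assay. Compound 2 `c1cnc2c(c1)CN[C@@H](CN(CCCCNC1CCOCC1)[C@H]1CCCc3cccnc31)C2` likewise gives only a limit, > 30000 nM. Compound 4 `c1cnc2c(c1)CN[C@@H](CN(CCCCNC1COC1)[C@H]1CCCc3cccnc31)C2` is not yet measured; it differs from compound 3 by (oxetan-3-yl)amino in place of methyl(oxan-4-yl)amino on a saturated chain carbon, four bonds along the chain from an amine nitrogen. For the measured compounds named here, two measured steps bear on this: an at least 3.5-fold lower number from compound 2 to compound 3 (0.55 log units; beyond the scatter), which compound 4 reverses by returning the hydrogen to that nitrogen, and an at least 3.5-fold lower number from compound 1 to compound 3 (0.55 log units; beyond the scatter), a ring exchange on the same nitrogen. a step that the two limits leave unreadable from compound 1 to compound 2 sits between the two limits and adds nothing readable. Loss of the methyl is expected to raise the number, a step of a 4.2-fold higher number from compound 3 to compound 4 (0.62 log units; beyond the scatter). Compound 4 is therefore estimated at 35000 nM, within 12000 nM to 100000 nM, most likely reported as a limit.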

Compound 4, half-maximal inhibitory concentration: 8800 nM
Estimate against measurement, compound 4: 4.0-fold (0.60 log units) above, outside the stated range (below it).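

In this assay a hydrogen on the amine nitrogen no longer means a limit: with (oxetan-3-yl)amino in place of methyl(oxan-4-yl)amino there is a 1.0-fold higher number from compound 3 to compound 4 (0.02 log units; within the scatter). With that hydrogen kept, the ring on the nitrogen decides the reading, with oxetan-3-yl in place of oxan-4-yl giving an at least 3.4-fold lower number from compound 2 to compound 4 (0.53 log units; beyond the scatter) and the same group set against the 4,4-difluorocyclohexyl side giving an at least 3.4-fold lower number from compound 1 to compound 4 (0.53 log units; beyond the scatter). Both of these steps start from a limit of the assay: the limit of > 30000 nM in this assay, at which 2 of the 4 values shown sit. Open, going by these compounds, is what a methyl on that nitrogen of compound 4 would do. Also open, on these data alone, is how a cyclopropyl group or an acetyl group there would read.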